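This account rests on a few compounds, and the source may have more. Where it says the series, first, only, none or still open, it means among the compounds named here.

Three close relatives built on one shared core have been tested in a functional assay on HT-29 cells (Homo sapiens) for cytotoxicity, read by sulforhodamine B assay; a lower number here means a stronger inhibitor of growth, a higher number a weaker inhibitor of growth. Compound 1 `O=c1oc2ccccc2cc1-c1cn2nc(-c3c([O-])[o+]nn3-c3ccc(Cl)cc3)sc2n1` gives 4 ug/mL, compound 2 `COc1ccc(-n2n[o+]c([O-])c2-c2nn3cc(-c4cc5cc(Cl)ccc5oc4=O)nc3s2)cc1` gives 3.68 ug/mL, and compound 3 `O=c1oc2ccc(Br)cc2cc1-c1cn2nc(-c3c([O-])[o+]nn3-c3ccccc3)sc2n1` gives 5.6 ug/mL. On these numbers compound 2 stands at the low end of the three, yet its gaps to compound 1 and to compound 3 both lie within the scatter, so the three cannot be told apart. Compound 4 `O=c1oc2ccc(Cl)cc2cc1-c1cn2nc(-c3c([O-])[o+]nn3-c3ccc(Cl)cc3)sc2n1` is still unmeasured and differs from compound 2 in one place: chloro in place of methoxy on an aromatic carbon. Among the compounds with values here, no measured pair shows this kind of change, so nothing anchors its effect. The expected step of a 1.1-fold higher number from compound 2 to compound 4 (0.04 log units; within the scatter) is one that stays within the scatter. Compound 4 is therefore estimated at 4 ug/mL, expected to fall between 2 ug/mL and 8 ug/mL.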

Compound 4, concentration for 50% growth inhibition: 8 ug/mL
The estimate for compound 4 lay 2.0-fold (0.30 log units) below the measured number; measured number inside the range.
By their numbers in this assay, from the lowest: compounds 2, 1, 3 and 4 (each within the scatter of the next, the first and the last beyond it).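

In this assay, within the data shown here, going from 4-methoxyphenyl to 4-chlorophenyl gives a 2.2-fold higher number from compound 2 to compound 4 (0.34 log units; beyond the scatter) and is a modest weakening of growth inhibition, the first step here to clear the scatter. Chloro in place of hydrogen on an aromatic carbon gives a 2.0-fold higher number from compound 1 to compound 4 (0.30 log units; within the scatter) and so shows no clear effect on its own. No measurement here explains either step. Going by these compounds, what an amine or a carboxylic acid would do at this place on the ring remains open. On these data alone, whether methoxy to chloro gives a similar step with other groups elsewhere on the shared core also remains open.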